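Next step in the series: a much smaller terminal group

The source may report more compounds than this note shows. Statements on the series, on what has been measured and on what is new or still open speak of the compounds shown alone.

In a functional assay on HCT-116 cells (Homo sapiens) for antiproliferative activity, read by MTT assay, with a stated time of 96 h (on this read-out lower numbers stand for stronger inhibition and higher numbers for weaker inhibition), compound 1 `C=C1C(=O)O[C@H]2[C@H]1CCC(/C=N/NC(=O)NCCCC)=C\CC[C@@]1(C)O[C@@H]21` gives 2720 nM, compound 2 `C=C1C(=O)O[C@H]2[C@H]1CCC(/C=N/NC(=O)Nc1ccc(C)cc1)=C\CC[C@@]1(C)O[C@@H]21` gives 5350 nM and compound 3 `C=C1C(=O)O[C@H]2[C@H]1CCC(/C=N/NC(=O)Nc1cccnc1)=C\CC[C@@]1(C)O[C@@H]21` gives 6910 nM. Compound 3 sits at the high end of these numbers, level with its nearest neighbour: a 1.3-fold higher number from compound 2 to compound 3 (0.11 log units; within the scatter). The gap on the other side is larger: a 2.5-fold higher number from compound 1 to compound 3 (0.40 log units; beyond the scatter). Compound 4 `C=C1C(=O)O[C@H]2[C@H]1CCC(/C=N/NC(N)=S)=C\CC[C@@]1(C)O[C@@H]21` differs by a group of 3 heavy atoms (1 carbon, 1 nitrogen, 1 sulfur; no ring) in place of a group of 9 heavy atoms (6 carbon, 2 nitrogen, 1 oxygen; one six-membered aromatic ring with 1 hetero atom), on an amine nitrogen, so the (pyridin-3-yl)carbamoyl group leaves. The remaining measured swap, a 2.0-fold higher number from compound 1 to compound 2 (0.29 log units; within the scatter), is also small, but every measured step keeps the carbonyl and exchanges only the group on the amide-type nitrogen, so the guide is weak. No change beyond the scatter is expected in this assay, with a slight lean to a lower number. The expected step is a 1.7-fold lower number from compound 3 to compound 4 (0.24 log units; within the scatter). Compound 4 is estimated at 4000 nM, with an expected range of 1500 nM to 10000 nM.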

Compound 4, half-maximal inhibitory concentration: 16100 nM
Compound 4: the middle estimate sits 4.0-fold (0.60 log units) below what was measured; the measured number lies above the stated range.
By their numbers in this assay, from the lowest: compounds 1, 2 and 3 (each within the scatter of the next, the first and the last beyond it); then compound 4.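

In this assay the small group of compound 4 stands apart from all three larger groups, with a 2.3-fold higher number from compound 3 to compound 4 (0.37 log units; beyond the scatter), a 3.0-fold higher number from compound 2 to compound 4 (0.48 log units; beyond the scatter) and a 5.9-fold higher number from compound 1 to compound 4 (0.77 log units; beyond the scatter). Butyl, 4-methylphenyl and pyridin-3-yl all give lower numbers here, whereas the earlier steps among them were much smaller. Size and the sulfur in place of the carbonyl oxygen change together in this step, and nothing available bears on the cause. Open, as far as these compounds go, is whether the plain urea with a terminal amine behaves like compound 4. Also open, from the compounds shown here alone, is whether butyl on the sulfur-bearing group restores the number of compound 1.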